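Chloro to methoxy on the fused aromatic ring

This account rests on a few compounds, and the source may have more. Where it says the series, first, only, none or still open, it means among the compounds named here.

Compound 1 `C1=NCC(CC2=Cc3ccccc3CC2)N1` carries the bare fused core; in an assay on isolated protein for binding affinity to Adrenergic receptor alpha-1 (Rattus norvegicus), read by radioligand binding, in the presence of a further agent that is not named here (a lower number here means a stronger inhibitor, a higher number a weaker inhibitor), compound 1 gives 398 nM. Compound 2 `Clc1cccc2c1C=C(CC1CN=CN1)CC2` adds a chloro on an aromatic carbon, and in this assay compound 2 gives 398 nM. Compound 3 `Fc1cccc2c1C=C(CC1CN=CN1)CC2` carries a fluoro at the same position, and in this assay compound 3 gives 501 nM. Compound 2 stands level with compound 1 at the digits shown, the two lowest of the three numbers; the step of no change at the digits printed from compound 1 to compound 2 (within the scatter) and the step of a 1.3-fold higher number from compound 2 to compound 3 (0.10 log units; within the scatter) both stay within the scatter, as does a 1.3-fold higher number from compound 1 to compound 3 (0.10 log units; within the scatter).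

Compound 4 `COc1cccc2c1C=C(CC1CN=CN1)CC2` differs from compound 2 by methoxy in place of chloro on an aromatic carbon. For the measured compounds named here, the only steps that bear on this position are the halogen exchanges, and none of them moved this assay beyond the scatter. Going by the values given here, no measured step covers the entry of a hydrogen-bond acceptor here, so the estimate rests on the flatness seen so far. The step of a 1.3-fold higher number from compound 2 to compound 4 (0.10 log units; within the scatter) is therefore expected to stay within the scatter. Compound 4 is estimated at 500 nM, with a range from 200 nM to 1250 nM.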

Compound 4, inhibition constant: 158 nM
Beside the measured number, compound 4's estimate is 3.2-fold (0.50 log units) above it; the whole stated range lies above it.
By their numbers in this assay, from the lowest: compound 4; then compounds 1, 2 and 3 (each within the scatter of the next).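

Methoxy in place of chloro gives a 2.5-fold lower number from compound 2 to compound 4 (0.40 log units; beyond the scatter) in this assay and is the first change at this place on the aromatic ring to go beyond the scatter. The same holds against the other two compounds, with a 3.2-fold lower number from compound 3 to compound 4 (0.50 log units; beyond the scatter) and a 2.5-fold lower number from compound 1 to compound 4 (0.40 log units; beyond the scatter) as the remaining steps, so compound 4 has the lowest number of the four. This place is therefore not indifferent to substitution, although hydrogen, chloro and fluoro stay within the scatter of one another, and nothing available explains the shift.

A single methoxy compound cannot separate the entering oxygen, which brings the hydrogen-bond acceptor, from the added carbon. Open, too, is whether hydroxy or ethoxy at this place would keep the lower number, and whether methoxy elsewhere on the aromatic ring would do the same.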